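Swapping a Furan for a Pyridine on the Shared Core

A few compounds are considered here, and "the series" means these few. Any claim that something is new, unique, unknown or untested is made for them only; others in the source may bear on it.

Compound 2 `Oc1cccc(-c2cc(-c3ccc(Cl)cc3)nc(-c3ccco3)c2)c1` gives 8190 nM in an ADME assay on HEK293 cells (Homo sapiens) for cytotoxicity, read by CCK-8 assay and cell counting, with a stated time of 2 days; a higher number here means a weaker inhibitor, a lower number a stronger inhibitor. Compound 1 `Oc1cccc(-c2cc(-c3ccc(Cl)cc3)nc(-c3cccs3)c2)c1` gives 11800 nM in this assay, and the two values lie within the scatter of each other. Compound 3 `Oc1cccc(-c2cc(-c3ccncc3)nc(-c3ccc(Cl)cc3)c2)c1` differs from compound 2 in one place: pyridin-4-yl in place of furan-2-yl on an aromatic carbon. Among the measured compounds shown here, the only measured step, a 1.4-fold lower number from compound 1 to compound 2 (0.16 log units; within the scatter), exchanged one five-membered aromatic ring for another and stayed within the scatter. For the measured compounds named here, no measured step covers a six-membered aromatic ring with one hetero atom entering at this place, so no change beyond the scatter is expected, a 1.1-fold higher number from compound 2 to compound 3 (0.04 log units; within the scatter). Compound 3 is therefore estimated at 9000 nM, with a range from 4000 nM to 25000 nM.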

Compound 3, half-maximal inhibitory concentration: 2890 nM
Estimate against measurement, compound 3: 3.1-fold (0.49 log units) above; the whole stated range lies above it.
By their numbers in this assay, from the lowest: compound 3; then compounds 2 and 1 (each within the scatter of the next).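

Replacing either five-membered ring with pyridin-4-yl gives a 2.8-fold lower number from compound 2 to compound 3 (0.45 log units; beyond the scatter) and a 4.1-fold lower number from compound 1 to compound 3 (0.61 log units; beyond the scatter) whereas exchanging the two five-membered rings for each other stayed within the scatter. The group on this aromatic carbon can therefore shift the number in this assay modestly, and among these compounds only the six-membered ring does so. Nothing available explains why this ring gives the lower number.

Going by these compounds, whether the shift follows the ring size or the ring nitrogen stays open, and an unsubstituted phenyl ring at this place would help separate the two. On these data alone, how an amine or a carboxylic acid would read here is also open.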